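Removing a methyl from a compound at the limit

The source may report more compounds than this note shows. Statements on the series, on what has been measured and on what is new or still open speak of the compounds shown alone.

Compound 1 `Cc1ccc(-c2nc3ccccn3c2Sc2ccccc2)cc1` gives > 100000 nM (a limit)
Compound 2 `COc1ccc(-c2nc3ccccn3c2Sc2ccccc2)cc1` gives 91700 nM (a number)
Compound 3 `Cc1ccc2nc(-c3ccc(Cl)cc3)c(Sc3ccccc3)n2c1` gives > 100000 nM (a limit)

In an ADME assay on NIH3T3 cells (Mus musculus) for inhibition, read by MTT assay, with a stated time of 48 h (on this read-out higher numbers stand for weaker inhibition and lower numbers for stronger inhibition), compound 3 stands at a limit (> 100000 nM) and has no number. Most of the series sits there too, as the limit of > 100000 nM in this assay, at which 2 of the 3 values shown sit, records. Compound 4 `Clc1ccc(-c2nc3ccccn3c2Sc2ccccc2)cc1` differs from compound 3 as follows: hydrogen in place of methyl on an aromatic carbon. Going by the values given here, the one measured step (an at least 1.0-fold lower number from compound 1 to compound 2 (0.03 log units; that floor lies within the scatter)) is a different change, methoxy in place of methyl on an aromatic carbon, and its floor lies within the scatter. No step beyond the scatter, in either direction, is therefore expected in this assay for this change. The expected step is a number no higher from compound 3 to compound 4 (the limit leaves the size open) on this estimate. For compound 4 the estimated value is 100000 nM (range 50000 nM to 200000 nM), and a report as a limit alone is also expected to be likely.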

Compound 4, half-maximal inhibitory concentration: > 100000 nM
Compound 4: a limit, no number; the forecaster's own chance of this, stated with the estimate: 65%; the middle value sits exactly at the limit.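

In this assay compound 4 is reported only as a limit, > 100000 nM, so hydrogen in place of methyl on an aromatic carbon yields no number for comparison. The steps from compound 3 and from compound 1 to compound 4 cannot be read, while chloro in place of methoxy on an aromatic carbon gives an at least 1.0-fold higher number from compound 2 to compound 4 (0.03 log units; that floor lies within the scatter). Compound 4 thus joins most of the compounds shown: the limit of > 100000 nM in this assay, at which 3 of the 4 values shown sit.

The compounds shown leave open whether an amine or a carboxylic acid in place of the chloro would give a number clearly lower than the value of compound 2, 91700 nM. They also leave open what a longer chain in place of the methyl would give.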